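Swapping the Aryl Group on a Shared Quinolone Core

A few compounds are considered here, and "the series" means these few. Any claim that something is new, unique, unknown or untested is made for them only; others in the source may bear on it.

Three compounds in this set share one core and were tested in a functional assay on A549 cells (Homo sapiens) for inhibition, read by MTT assay, with a stated time of 72 h; a higher number here means a weaker inhibitor, a lower number a stronger inhibitor. Compound 1, `Cn1ccc2c(Oc3ccc(NC(=O)c4cn(-c5ccc(Br)cc5F)c5ccccc5c4=O)cc3F)ccnc21`, gives 1520 nM in this assay. Compound 2, `Cn1ccc2c(Oc3ccc(NC(=O)c4cn(-c5ccc(C(F)(F)F)cc5Cl)c5ccccc5c4=O)cc3F)ccnc21`, carries the change 2-chloro-4-(trifluoromethyl)phenyl in place of 4-bromo-2-fluorophenyl on an aromatic nitrogen and gives 2050 nM in this assay, a step of a 1.3-fold higher number from compound 1 to compound 2 (0.13 log units; within the scatter). Compound 3, `O=C(Nc1ccc(Oc2ccnc3[nH]ccc23)c(F)c1)c1cn(-c2ccc(Br)cc2F)c2ccccc2c1=O`, differs from compound 1 by hydrogen in place of methyl on an aromatic nitrogen; in this assay compound 3 gives 1150 nM, a step of a 1.3-fold lower number from compound 1 to compound 3 (0.12 log units; within the scatter). All three numbers therefore sit within the usual scatter of one another, so none can be called stronger or weaker than the rest.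

Compound 4, `O=C(Nc1ccc(Oc2ccnc3[nH]ccc23)c(F)c1)c1cn(-c2ccc(C(F)(F)F)cc2Cl)c2ccccc2c1=O`, has not been measured. It stands to compound 3 as compound 2 stands to compound 1: the change is 2-chloro-4-(trifluoromethyl)phenyl in place of 4-bromo-2-fluorophenyl on an aromatic nitrogen, and the place where it occurs is described in the same words for both pairs, so this is the same change made on the core of compound 3 rather than on the core of compound 1. The two cores differ only by hydrogen in place of methyl on an aromatic nitrogen.

For the measured compounds named here, the only guide is the measured pair: from compound 1 to compound 2 the step was a 1.3-fold higher number from compound 1 to compound 2 (0.13 log units; within the scatter), within the scatter. The step from compound 3 to compound 4 in this assay is expected to be about a 1.3-fold higher number from compound 3 to compound 4 (0.12 log units; within the scatter), because the same change gave a 1.3-fold higher number from compound 1 to compound 2 (0.13 log units; within the scatter) before. On that basis compound 4 is estimated at 1500 nM in this assay, with a plausible range from 700 nM to 3500 nM.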

Compound 4, half-maximal inhibitory concentration: 1620 nM
Compound 4: the middle estimate sits 1.1-fold (0.03 log units) below what was measured, within the range that was stated.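

On the core of compound 3, the aryl swap gives a 1.4-fold higher number from compound 3 to compound 4 (0.15 log units; within the scatter) in this assay, and this step agrees with the one seen on the core of compound 1: the same change on two cores in this assay, a 1.3-fold higher number (0.13 log units; within the scatter) from compound 1 to compound 2 and a 1.4-fold higher number (0.15 log units; within the scatter) from compound 3 to compound 4, 1.0-fold (0.02 log units) apart, within the scatter of two such steps

The other change, hydrogen in place of methyl on an aromatic nitrogen, gives a 1.3-fold lower number from compound 2 to compound 4 (0.10 log units; within the scatter), and it too agrees with its earlier counterpart: the same change on two cores in this assay, a 1.3-fold lower number (0.12 log units; within the scatter) from compound 1 to compound 3 and a 1.3-fold lower number (0.10 log units; within the scatter) from compound 2 to compound 4, 1.0-fold (0.02 log units) apart, within the scatter of two such steps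

So in these four compounds the aryl swap carries from one core to the other with no visible difference, but every step lies within the scatter, so this shows only that neither change moved the number measurably on either core, not that either change has a real effect of its own or that the two changes would stay independent in a series where the steps are larger. Two cores and one pair of aryl groups are also too few to support a general rule.

The compounds shown leave open what other groups on that aromatic nitrogen of the shared core would do, such as an unsubstituted phenyl or a phenyl carrying an amine or a carboxylic acid. They also leave open whether a longer chain than methyl on the other aromatic nitrogen would shift the number beyond the scatter.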